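From cyclohexyl to 4-ethoxyphenyl on the amine nitrogen

The source may report more compounds than this note shows. Statements on the series, on what has been measured and on what is new or still open speak of the compounds shown alone.

In a functional assay on HeLa cells (Homo sapiens) for inhibition, read by sulforhodamine B assay (a lower number here means a stronger inhibitor, a higher number a weaker inhibitor), compound 2 (`O=C1C=C(NC2CCCCC2)C(=O)c2c1nc1n2[C@H]2OC[C@@H](O)[C@H]2OC1`) gives > 16000 nM as a limit of the assay and not a number. Compound 1 (`O=C1C(Nc2ccccc2F)=CC(=O)c2c1nc1n2[C@H]2OC[C@@H](O)[C@H]2OC1`) gives 9820 nM as a measured number. Compound 3 (`COc1ccc(NC2=CC(=O)c3c(nc4n3[C@H]3OC[C@@H](O)[C@H]3OC4)C2=O)cc1`) gives > 8000 nM as a limit of the assay. Compound 4 (`CCOc1ccc(NC2=CC(=O)c3nc4n(c3C2=O)[C@H]2OC[C@@H](O)[C@H]2OC4)cc1`) differs from compound 2 by one change (4-ethoxyphenyl in place of cyclohexyl on an amine nitrogen) on the amine nitrogen. Within the data shown here, the only measured step that bears on this (a step that the limit leaves unreadable from compound 1 to compound 3) has no readable size and sets no size for the change. Among the measured compounds shown here, the sole number, 9820 nM for compound 1, is the anchor for the expectation. The expected step (an at least 1.3-fold lower number from compound 2 to compound 4 (0.12 log units; that floor lies within the scatter)) is small and toward stronger inhibition, hardly beyond the scatter. Compound 4 is estimated at 12000 nM (expected range 5000 nM to 30000 nM).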

Compound 4, half-maximal inhibitory concentration: 3110 nM
For compound 4 the middle estimate is 3.9-fold (0.59 log units) above the measured one, outside the stated range (below it).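

On the amine nitrogen, 4-ethoxyphenyl in place of cyclohexyl gives an at least 5.1-fold lower number from compound 2 to compound 4 (0.71 log units; beyond the scatter) in this assay. That size is only a floor, because compound 2 stands at a limit of the assay: the limit of > 16000 nM in this assay, at which 1 of the 4 values shown sits.
Compound 4 gives 3110 nM, and compound 1, with 2-fluorophenyl at this place, gives 9820 nM, so a substituted phenyl at this nitrogen now has two measured numbers. Compound 3, with 4-methoxyphenyl, holds only a limit, > 8000 nM, and the comparison of methoxy with ethoxy stays unread. From the compounds shown here alone, whether a longer chain such as 4-butoxyphenyl, or a 4-aminophenyl group, changes the number remains open.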